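The compounds below may be only part of what the source reports. "The series", "measured", "known", "first", "only" and "open" are said of these compounds alone.

Measured compounds in a functional assay on NCI-H23 cells (Homo sapiens) for inhibition, read by sulforhodamine B assay, with a stated time of 48 h, tested at 0.01 uM; on this read-out lower numbers stand for a stronger effect and higher numbers for a weaker effect at the one concentration tested:

- compound 1 `COc1cc(Cl)cc(-c2nn(-c3cccc(NC(=O)Nc4ccc(Cl)c(C(F)(F)F)c4)c3)cc2-c2ccncc2)c1` gives 90%
- compound 2 `COc1cc(Cl)cc(-c2nn(-c3cccc(NC(=O)Nc4cc(C(F)(F)F)cc(C(F)(F)F)c4)c3)cc2-c2ccncc2)c1` gives 94%
- compound 3 `COc1cc(Cl)cc(-c2nn(-c3cccc(NC(=O)Nc4ccc(Cl)c(Cl)c4)c3)cc2-c2ccncc2)c1` gives 93%

On these numbers compound 3 stands second highest of the three, with compound 2 nearest and compound 1 furthest, and both of those gaps lie within the scatter. In other words, the three compounds cannot be told apart on this assay, and all of them show only a weak effect at the one concentration tested.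

Compound 4 `COc1cc(Cl)cc(-c2nn(-c3cccc(NC(=O)Nc4cccc(C(F)(F)F)c4)c3)cc2-c2ccncc2)c1` differs from compound 3 in one place: 3-(trifluoromethyl)phenyl in place of 3,4-dichlorophenyl on an amide-type nitrogen. Among the measured compounds shown here, the only measured step that bears on this is a number 3 percentage points higher from compound 1 to compound 3 (within the scatter), which exchanged a trifluoromethyl for a chloro and stayed within the scatter. Compound 1 and compound 2, which both carry trifluoromethyl on the terminal phenyl, also sit within the scatter of compound 3. For the measured compounds named here, nothing among the measured compounds therefore points to a move beyond the scatter, and the expected step is no change at the digits printed from compound 3 to compound 4 (within the scatter) in this assay. Compound 4 is accordingly estimated at 93%, within 84% to 100%.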

Compound 4, a percentage reported as activity, at one concentration (the size of the read-out at that concentration, not a potency): 97%
The estimate for compound 4 lay 4 percentage points below the measured number, within the range that was stated.
By their numbers in this assay, from the lowest: compounds 1, 3, 2 and 4 (each within the scatter of the next).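

In this assay, 3-(trifluoromethyl)phenyl in place of 3,4-dichlorophenyl on the amide-type nitrogen gives a number 4 percentage points higher from compound 3 to compound 4 (within the scatter). Taking one trifluoromethyl away from the terminal phenyl gives a number 3 percentage points higher from compound 2 to compound 4 (within the scatter), and taking the chloro away from it gives a number 7 percentage points higher from compound 1 to compound 4 (within the scatter). Among the compounds shown here, compound 4 thus adds a terminal phenyl carrying trifluoromethyl alone, a pattern the earlier compounds did not show, and taking away the other ring substituent of compound 1 or compound 2 does not leave the scatter. No measured finding is available to explain these numbers. It remains open whether an amine or a carboxylic acid on this terminal phenyl would move the number beyond the scatter, and how any of these compounds would read at a higher concentration.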